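A few compounds are considered here, and "the series" means these few. Any claim that something is new, unique, unknown or untested is made for them only; others in the source may bear on it.

Compound 2 `CCc1ccc(Nc2cc(NC(=O)Nc3cc(OC)cc(OC)c3)ncn2)cc1` was tested in a functional assay on HCC827 cells (Homo sapiens) for inhibition, read by MTT assay, with a stated time of 48 h, tested at 10 uM (on this read-out higher numbers stand for more inhibition at the one concentration tested (going by the name of the read-out) and lower numbers for less inhibition), where compound 2 gives 66.2%. Among the three compounds measured, this is the second highest number: compound 3 `COc1ccc(F)cc1Nc1cc(NC(=O)Nc2c(Cl)cccc2Cl)ncn1` gives 78%, a number beyond the scatter above it, and compound 1 `COc1cc(NC(=O)Nc2cc(Nc3ccc(C(C)(C)C)cc3)ncn2)cc(OC)c1` gives 32.7%, a number beyond the scatter below it.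

Compound 4 `COc1cc(NC(=O)Nc2cc(Nc3cccc(C(C)(C)C)c3)ncn2)cc(OC)c1` has not yet been measured. It differs from compound 2 in one place: 3-(tert-butyl)phenyl in place of 4-ethylphenyl on a nitrogen on an aromatic ring.

Going by the values given here, one measured step bears on this change. From compound 1 to compound 2 the read-out rose by a number 33.5 percentage points higher from compound 1 to compound 2 (beyond the scatter), when ethyl replaced tert-butyl on an aromatic carbon. Among the compounds with values here, compound 4 brings a tert-butyl group back, though as 3-(tert-butyl)phenyl rather than in the arrangement found in compound 1, so the two cases are not the same and no measured pair shows what that arrangement does.

Because the return of tert-butyl reverses the change that gave a number 33.5 percentage points higher from compound 1 to compound 2 (beyond the scatter), the expected step for compound 4 is a number 24.2 percentage points lower from compound 2 to compound 4 (beyond the scatter), a drop, with wide uncertainty. Compound 4 is therefore estimated at 42%, within a range from 20% to 66%.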

Compound 4, a percentage reported as inhibition, at one concentration (the size of the read-out at that concentration, not a potency): 48.7%
Compound 4: middle estimate off by 6.7 percentage points, on the low side, within the range that was stated.
By their numbers in this assay, from the lowest: compound 1; then compound 4; then compound 2; then compound 3.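

In this assay the tert-butyl group stays the same and only its place on the ring changes: 3-(tert-butyl)phenyl in place of 4-(tert-butyl)phenyl gives a number 16 percentage points higher from compound 1 to compound 4 (beyond the scatter) and so shows that the read-out at this position depends on where the group sits, not only on which group it is. Putting 3-(tert-butyl)phenyl in place of 4-ethylphenyl gives a number 17.5 percentage points lower from compound 2 to compound 4 (beyond the scatter) and so shows that the new placement does not bring the read-out back up to that of compound 2. Nothing available explains either difference.

The compounds shown leave open how 3-ethylphenyl would compare, which would separate the choice of group from its place on the ring. Also open, going by these compounds, is what an amine or a carboxylic acid on this ring would do.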